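Substituent swap on the pyridine-linked piperidine series

The compounds below may be only part of what the source reports. "The series", "measured", "known", "first", "only" and "open" are said of these compounds alone.

Measured so far in an assay on membranes from brain for binding affinity to Lysophosphatidylserine lipase ABHD12 (Mus musculus), read by fluorescence, with a stated time of 20 min; a lower number here means a stronger inhibitor, a higher number a weaker inhibitor:
compound 1 `S=C(Nc1cccnc1)NC1CCN(c2cc(Cl)ccn2)CC1` gives 2100 nM
compound 2 `COc1ccc(Oc2ccnc(N3CCC(NC(=S)Nc4cccnc4)CC3)c2)cc1` gives 2900 nM
compound 3 `FC(F)(F)c1ccnc(N2CCC(NC(=S)Nc3cccnc3)CC2)c1` gives 640 nM

The three compounds share one core and differ only in the group on the aromatic carbon. Compound 3 holds the lowest of the three numbers in this assay: the step of a 3.3-fold lower number from compound 1 to compound 3 (0.52 log units; beyond the scatter) and the step of a 4.5-fold lower number from compound 2 to compound 3 (0.66 log units; beyond the scatter) both lie beyond the scatter, whereas the step of a 1.4-fold higher number from compound 1 to compound 2 (0.14 log units; within the scatter) does not, so chloro and 4-methoxyphenoxy cannot be ranked against each other.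

Compound 4 `S=C(Nc1cccnc1)NC1CCN(c2cc(OCC3CC3)ccn2)CC1` is not yet measured. Its change from compound 3 is cyclopropylmethoxy in place of trifluoromethyl on an aromatic carbon. For the measured compounds named here, the steps that bear on it are the two that install trifluoromethyl, a 3.3-fold lower number from compound 1 to compound 3 (0.52 log units; beyond the scatter) and a 4.5-fold lower number from compound 2 to compound 3 (0.66 log units; beyond the scatter); compound 4 reverses that move, and the closest precedent for an oxygen-linked group at this carbon is the 4-methoxyphenoxy of compound 2. A higher number is therefore expected, of a size comparable to those two steps. Relative to compound 3, the expected step is a 3.1-fold higher number from compound 3 to compound 4 (0.49 log units; beyond the scatter). For compound 4 the estimated value is 2000 nM, with a range from 700 nM to 6000 nM.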

Compound 4, half-maximal inhibitory concentration: 4700 nM
Beside the measured number, compound 4's estimate is 2.4-fold (0.37 log units) below it; the range from low to high includes it.
By their numbers in this assay, from the lowest: compound 3; then compounds 1, 2 and 4 (each within the scatter of the next, the first and the last beyond it).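

In this assay, for the compounds shown here, a 7.3-fold higher number from compound 3 to compound 4 (0.87 log units; beyond the scatter) is the largest step so far at the carbon opposite the ring nitrogen, and trifluoromethyl now holds the lowest number against an oxygen-linked group ending in an alkyl as well as one ending in an aryl. Exchange on the oxygen itself gives a 1.6-fold higher number from compound 2 to compound 4 (0.21 log units; within the scatter), so cyclopropylmethyl and 4-methoxyphenyl on that oxygen cannot be ranked, while a 2.2-fold higher number from compound 1 to compound 4 (0.35 log units; beyond the scatter) separates cyclopropylmethoxy from chloro, even though 4-methoxyphenoxy and chloro remain unranked against each other. No information at hand accounts for these differences.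

Still open, on these data alone, is whether the low number of compound 3 belongs to trifluoromethyl specifically or would extend to other groups at this carbon, such as a nitrile, a methyl, or a dimethylamino group, and whether a bare methoxy would sit with the two larger oxygen-linked groups. As far as these compounds go, it is also open whether the same order holds when the shared core is changed elsewhere, since every comparison here rests on this one carbon.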